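A few compounds are considered here, and "the series" means these few. Any claim that something is new, unique, unknown or untested is made for them only; others in the source may bear on it.

Of the compounds shown here, three built on one shared core have been tested in an ADME assay on HUVEC cells (Homo sapiens) for antiproliferative activity, read by MTT assay, with a stated time of 48 h; on this read-out lower numbers stand for stronger inhibition and higher numbers for weaker inhibition. Compound 1 `N#CC1=C(N)Oc2c(c3nc4ccccc4nc3c3ccccc23)C12C(=O)N(Cc1cnnn1-c1ccc(Br)cc1)c1ccccc12` gives > 50000 nM, which is a limit of the measurement and not a number. Compound 2 `Cc1ccc(-n2nncc2CN2C(=O)C3(C(C#N)=C(N)Oc4c3c3nc5ccccc5nc3c3ccccc43)c3ccccc32)c(C)c1` likewise gives > 50000 nM, again a limit. Within the data shown here, compound 3 `N#CC1=C(N)Oc2c(N)cc3nc4ccccc4nc3c2C12C(=O)N(Cc1cnnn1-c1ccccc1Br)c1ccccc12` gives 34200 nM, the only actual number among the three. Whether compound 3 stands apart from the other two cannot be said, since their results are limits, and the step that the two limits leave unreadable from compound 1 to compound 2 runs from one limit to another, so its size is unreadable.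

Compound 4 `CCc1cccc(CC)c1-n1nncc1CN1C(=O)C2(C(C#N)=C(N)Oc3c(N)cc4nc5ccccc5nc4c32)c2ccccc21` is the unmeasured one. It differs from compound 3 in a single place: 2,6-diethylphenyl in place of 2-bromophenyl on an aromatic nitrogen. Among the measured compounds shown here, the one measured step that touches the group on the aromatic nitrogen, a step that the two limits leave unreadable from compound 1 to compound 2, gives no readable size, so there is no measured guide to how large a change of this kind might be in this assay. The expectation is therefore no shift beyond the usual scatter, with a wide range, and a real chance that only a limit will be reported because two of the three known results sit at the limit of > 50000 nM in this assay, at which 2 of the 3 values shown sit. The estimated step is a 1.2-fold higher number from compound 3 to compound 4 (0.07 log units; within the scatter). Compound 4 is expected to give 40000 nM, within a range from 15000 nM to 100000 nM.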

Compound 4, half-maximal inhibitory concentration: > 50000 nM
Compound 4: only a limit was reported; the forecaster's own chance of this, stated with the estimate: 55%; middle value at least 1.2-fold (0.09 log units) from the limit.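

Among these compounds, the change from 2-bromophenyl to 2,6-diethylphenyl, on an aromatic nitrogen of the five-membered aromatic ring, gives the first step at this position with a readable size, an at least 1.4-fold higher number from compound 3 to compound 4 (0.16 log units; that floor lies within the scatter), while the step between compound 1 and compound 2 joins two limits and cannot be read. Only this floor is known, so the true step could be larger or could be no more than ordinary scatter, and a real loss of activity at this position is not shown. The entering group, with 10 heavy atoms in place of 7 and no bromine, does not give an actual number in this assay, and the set now rests mostly on limits: the limit of > 50000 nM in this assay, at which 3 of the 4 values shown sit.

Going by these compounds, whether the result follows from losing the bromine or from gaining the two ethyl groups stays open. A plain phenyl, a 2-ethylphenyl, or a phenyl carrying an amine or a carboxylic acid at this position could help to separate those two changes, provided that such compounds gave numbers and not limits.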